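From methoxycarbonyl to carbamoyl at the limit of tolerance

The compounds below may be only part of what the source reports. "The series", "measured", "known", "first", "only" and "open" are said of these compounds alone.

In an ADME assay on TZM cells (Homo sapiens) for cytotoxicity, read by XTT assay, with a stated time of 4 days (a higher number here means that more compound is tolerated, a lower number that less compound is tolerated), compound 3 `COC(=O)c1cc(N)c(Nc2ccc(C#N)cc2)cc1Oc1c(C)cc(CCC#N)cc1C` gives > 22700 nM, which is a limit and not a number. Compound 1 `Cc1cc(/C=C/C#N)cc(C)c1Oc1cc(Nc2ccc(C#N)cc2)c(N)cc1C(N)=O` likewise reaches only a limit, > 23600 nM. Compound 2 `CNC(=O)c1cc(N)c(Nc2ccc(C#N)cc2)cc1Oc1c(C)cc(CCC#N)cc1C` also gives only a limit, > 9100 nM. No exact half-maximal cytotoxic concentration is therefore available for any of the three.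

The next compound, compound 4 `Cc1cc(CCC#N)cc(C)c1Oc1cc(Nc2ccc(C#N)cc2)c(N)cc1C(N)=O`, follows from compound 3 through the change amino in place of methoxy on a carbonyl carbon, or methoxycarbonyl to carbamoyl.

Within the data shown here, the only measured step at this carbonyl carbon is a step that the two limits leave unreadable from compound 2 to compound 3, with methoxy in place of methylamino. It gives no usable size, so it offers no basis for predicting a direction. Without a readable step, no change beyond the usual scatter is expected in this assay, and the estimated step is an at least 1.0-fold lower number from compound 3 to compound 4 (0.01 log units; that floor lies within the scatter). Compound 4 is estimated at 22000 nM, with an expected range of 9000 nM to 60000 nM, and it is expected that the assay will probably report a limit again.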

Compound 4, half-maximal cytotoxic concentration in the TZM assay: > 9400 nM
Compound 4: no number, only a limit; the forecaster's own chance of this, stated with the estimate: 85%; the middle value is on the limit's open side.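

In the TZM assay compound 4 gives > 9400 nM, which is a limit and not a number. Compound 1, compound 2 and compound 3 also give only limits, so none of the steps from these three to compound 4 can be read. The compounds shown leave open where the exact half-maximal cytotoxic concentration of any of the four lies.

In a physicochemical assay for lipophilicity, at pH 7.4 (a lower number here means a more polar compound, a higher number a more lipophilic compound), compound 3 gives 4.15 and compound 4 gives 2.65.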